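A few compounds are considered here, and "the series" means these few. Any claim that something is new, unique, unknown or untested is made for them only; others in the source may bear on it.

Compound 1 `CCCC(CCC)C(=O)OC[C@H]1O[C@@H](n2cnc3c(N)ncnc32)[C@H](OC(=O)C(CCC)CCC)[C@]1(C)O` carries two (1-propylbutyl)carbonyl esters on the shared core. For the measured compounds named here, in a functional assay on MCF7 cells (Homo sapiens) for inhibition, read by MTT assay, with a stated time of 48 h (on this read-out higher numbers stand for weaker inhibition and lower numbers for stronger inhibition), compound 1 gives 57800 nM, and this is the only number the set offers, so compound 1 cannot be ranked against anything measured. Compound 2 `CCCC(CCC)C(=O)Nc1ncnc2c1ncn2[C@@H]1O[C@H](COC(=O)C(CCC)CCC)[C@@](C)(O)[C@H]1OC(=O)C(CCC)CCC` adds a third (1-propylbutyl)carbonyl group to the same core; in this assay compound 2 gives "nd(insoluble)" (no result reported), meaning that no value could be obtained for it. Compound 3 `CCCC(CCC)C(=O)OC[C@H]1O[C@@H](n2cnc3c(N)ncnc32)[C@H](O)[C@]1(C)O` is the next step. Relative to compound 1 it differs by hydrogen in place of (1-propylbutyl)carbonyl on an oxygen on a saturated carbon, so that ((1-propylbutyl)carbonyl)oxy becomes hydroxy at that position. Going by the values given here, no measured pair in the set shows what such a removal does in this assay, and nothing is known about how these compounds bind. The expected step is a 1.4-fold higher number from compound 1 to compound 3 (0.14 log units; within the scatter), which is small and without a firm direction beyond the usual scatter. Compound 3 is therefore estimated to give about 80000 nM in this assay, with a likely range running from 25000 nM to 250000 nM.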

Compound 3, half-maximal inhibitory concentration: > 200000 nM
Compound 3 was reported as a limit; the forecaster's own chance of this, stated with the estimate: 25%; at least 2.5-fold (0.39 log units) between middle value and limit.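

Replacing the (1-propylbutyl)carbonyl on this oxygen with hydrogen, so that ((1-propylbutyl)carbonyl)oxy becomes hydroxy, gives the set its first measured comparison at this position. In this assay, the change produces an at least 3.4-fold higher number from compound 1 to compound 3 (0.53 log units; beyond the scatter). On this read-out, a higher number means weaker inhibition, so the group at this position counts for something in this series: losing it weakens inhibition by more than the usual scatter. The full size of the step cannot be read because the result for compound 3 is a limit and not a number: the limit of > 200000 nM in this assay, at which 1 of the 3 values shown sits.

The compounds shown do not reveal what it is about the (1-propylbutyl)carbonyl group that matters here, or whether a small acetyl group or a longer chain at this oxygen would give a lower or higher number than compound 1. Compound 2 has no number, and steps involving it cannot be read. As far as these compounds go, the effect of its third (1-propylbutyl)carbonyl group remains unknown.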